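Ring nitrogen substitution in a fused seven-membered series

The source may report more compounds than this note shows. Statements on the series, on what has been measured and on what is new or still open speak of the compounds shown alone.

Measured so far:
compound 1 `Cc1nn(C)c2c1C(c1cccc(Cl)c1)=NCCN2CCCN(C)C` — > 10 mg/kg
compound 2 `Cc1nn(C)c2c1C(c1cccc(F)c1)=NCCN2` — 2.5 mg/kg

In a functional assay on the whole organism for positive allosteric modulation, with Rattus norvegicus as the target (a higher number here means that more compound is needed for the effect, a lower number that less compound is needed), compound 2 gives 2.5 mg/kg. This is the only number among the two results shown; the other result is a limit. Compound 1 reaches only a limit of the assay, > 10 mg/kg, and stands at the limit of > 10 mg/kg in this assay, at which 1 of the 2 values shown sits. For the measured compounds named here, no step between compound 1 and compound 2 is computed, since the two structures differ in more than one place; the two values show only that compound 2 yields a number where compound 1 does not.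

Compound 3 `Cc1nn(C)c2c1C(c1cccc(F)c1)=NCCN2CCCN(C)C` is the next compound to be measured in this assay. It differs from compound 2 in one place: 3-(dimethylamino)propyl in place of hydrogen on a nitrogen on an aromatic ring in a ring. Compound 1 carries the same 3-(dimethylamino)propyl chain on the same ring nitrogen.

Given that compound 1 with this chain sits at the limit of > 10 mg/kg in this assay, at which 1 of the 2 values shown sits, the expected step of a 4.0-fold higher number from compound 2 to compound 3 (0.60 log units; beyond the scatter) is upward, toward a larger dose needed, and beyond the usual scatter. Compound 3 is expected to give 10 mg/kg, within 3 mg/kg to 30 mg/kg. A result that is again only a limit is considered about as likely as a number.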

Compound 3, minimum effective dose: > 10 mg/kg
Compound 3: a limit, no number; the forecaster's own chance of this, stated with the estimate: 50%; the middle value sits exactly at the limit.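

For the compounds shown here, with the 3-fluorophenyl group held constant in this assay, 3-(dimethylamino)propyl in place of hydrogen on the nitrogen of the seven-membered non-aromatic ring gives an at least 4.0-fold higher number from compound 2 to compound 3 (0.60 log units; beyond the scatter), the first readable single-place step. This change alone takes the result from a number to a limit, so the step has a lower bound but no measured size. Compound 1 and compound 3 both carry the chain and both end at a limit, so the step between them cannot be read and the fluoro and chloro groups cannot be ranked when the chain is present: the limit of > 10 mg/kg in this assay, at which 2 of the 3 values shown sit.

Whether all substitution on this nitrogen carries the same penalty stays open, since only hydrogen and 3-(dimethylamino)propyl are shown there, and a methyl group, a shorter aminoethyl chain or a chain ending in a carboxylic acid could separate the effect of chain length from that of the terminal amine. From the compounds shown here alone, the effect of chloro in place of fluoro also stays open for the form with hydrogen on this nitrogen, the only form that yields a number in this assay.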